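This account rests on a few compounds, and the source may have more. Where it says the series, first, only, none or still open, it means among the compounds named here.

In a functional assay on MCF7 cells (Homo sapiens) for antiproliferative activity, read by MTT assay, with a stated time of 72 h (a lower number here means a stronger inhibitor, a higher number a weaker inhibitor), compound 1 `O=C(N/N=C/c1ccc([N+](=O)[O-])cc1)Nc1ccc(Oc2ccnc3[nH]ccc23)c(F)c1` gives 4000 nM, while compound 2 `CC(C)(C)c1cc(/C=N/NC(=O)Nc2ccc(Oc3ccnc4[nH]ccc34)c(F)c2)cc(C(C)(C)C)c1O` gives 840 nM. Compound 1 has the higher of these two numbers, and the gap between them lies beyond the scatter. Next in the series is compound 3 `O=C(N/N=C/c1cc(Br)c(O)c(Br)c1)Nc1ccc(Oc2ccnc3[nH]ccc23)c(F)c1`, not yet measured. Its change from compound 1 is 3,5-dibromo-4-hydroxyphenyl in place of 4-nitrophenyl on a carbon with a double bond to nitrogen, on a carbon with a double bond to nitrogen. Among the compounds with values here, no measured pair differing in one place exists yet, so the size of this step rests on thin evidence. A moderate fall in the number is expected in this assay, probably just beyond the scatter. The basis for that direction is compound 2 at 840 nM, the only other measured point. The expected move is a 2.7-fold lower number from compound 1 to compound 3 (0.43 log units; beyond the scatter). For compound 3 the estimated value is 1500 nM, with an expected range of 550 nM to 4000 nM.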

Compound 3, half-maximal inhibitory concentration: "not active" (no number reported)
For compound 3 the study gives words and no number, and the estimate cannot be compared.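

Within the data shown here, compound 3 is reported in this assay only as not active, without a number, so no step from compound 1 to compound 3 can be read. The compounds shown leave open how far 3,5-dibromo-4-hydroxyphenyl in place of 4-nitrophenyl moves the number. No available evidence bears on this result.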